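The compounds below may be only part of what the source reports. "The series", "measured", "known", "first", "only" and "open" are said of these compounds alone.

Compound 3 `Cc1ccc(S(=O)(=O)c2cnc3cc(F)ccc3c2N2CCC(C)CC2)cc1Cl` is a member of a small series built on a shared core carrying a sulfonyl group and a 4-methylpiperidine. In an assay on isolated protein for displacement of a labelled ligand from metabotropic glutamate receptor 5 (Homo sapiens), with a stated time of 60 min, tested at 1 uM (a lower number here means less inhibition, a higher number more inhibition at the concentration tested (going by the name of the read-out)), compound 3 gives 93%, level with compound 2 `CC1CCN(c2c(S(=O)(=O)c3ccccc3)cnc3cc(Cl)ccc23)CC1`, which gives 93%; together they stand highest of the three numbers. Within the data shown here, compound 1 `Cc1cc(C)cc(S(=O)(=O)c2cnc3cc(F)ccc3c2N2CCC(C)CC2)c1` gives 80%, and the step of a number 13 percentage points higher from compound 1 to compound 3 (beyond the scatter) is the only measured step on this position. Compound 4 `CC1CCN(c2c(S(=O)(=O)c3ccccc3)cnc3cc(F)ccc23)CC1` differs from compound 3 by phenyl in place of 3-chloro-4-methylphenyl on a sulfonyl sulfur. Compound 2 already carries phenyl on the sulfonyl sulfur and matches compound 3, so a step of no more than the scatter is expected, a number 3 percentage points lower from compound 3 to compound 4 (within the scatter). Compound 4 is therefore estimated at 90%, with a range from 79% to 97%.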

Compound 4, a percentage reported as inhibition, at one concentration (the size of the read-out at that concentration, not a potency): 87%
Beside the measured number, compound 4's estimate is 3 percentage points above it; low and high end bracket the measured number.
By their numbers in this assay, from the lowest: compounds 1, 4, 2 and 3 (each within the scatter of the next, the first and the last beyond it).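

On the sulfonyl sulfur, phenyl in place of 3-chloro-4-methylphenyl gives a number 6 percentage points lower from compound 3 to compound 4 (within the scatter), and phenyl in place of 3,5-dimethylphenyl gives a number 7 percentage points higher from compound 1 to compound 4 (within the scatter), so neither substituted ring stands beyond the scatter from phenyl, although they do from each other. Fluoro in place of chloro on an aromatic carbon, a change the earlier compounds did not isolate, gives a number 6 percentage points lower from compound 2 to compound 4 (within the scatter). No measurement given here accounts for these steps. Still open, from the compounds shown here alone, is how an amine or a carboxylic acid on the phenyl ring, or a morpholine in place of the 4-methylpiperidine, would read.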